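The compounds below may be only part of what the source reports. "The series", "measured", "known", "first", "only" and "open" are said of these compounds alone.

- compound 1 `C=C(Br)C(=O)Nc1cccc(/C=C/C(=O)Nc2ccc(F)cc2)c1`: 16800 nM
- compound 2 `C=C(Br)C(=O)Nc1cccc(/C=C/C(=O)Nc2ccc(F)c(F)c2)c1`: 1900 nM
- compound 3 `C=C(Br)C(=O)Nc1cccc(/C=C/C(=O)Nc2ccc(C)cc2)c1`: 1500 nM

These values come from a functional assay on HeLa cells (Homo sapiens) for inhibition, read by MTT assay, with a stated time of 72 h; a higher number here means a weaker inhibitor, a lower number a stronger inhibitor. The low end of the range is shared, with a 1.3-fold lower number from compound 2 to compound 3 (0.10 log units; within the scatter). The high end is far off, with an 11-fold lower number from compound 1 to compound 3 (1.05 log units; beyond the scatter).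

Compound 4 `C=C(Br)C(=O)Nc1cccc(/C=C/C(=O)Nc2ccc(OCC)cc2)c1` carries ethoxy in place of methyl on an aromatic carbon, para to a large group: ethoxy in place of methyl on an aromatic carbon.

For the measured compounds named here, no measured compound bears ethoxy, so the data do not show a direction for this change. The closest measured swap is methyl in place of fluoro on an aromatic carbon, an 11-fold lower number from compound 1 to compound 3 (1.05 log units; beyond the scatter), which shows that one substituent can matter a great deal in this assay. Against this, a 1.3-fold lower number from compound 2 to compound 3 (0.10 log units; within the scatter) shows that two quite different substitution patterns can give values within the scatter. On balance, no step beyond the scatter is expected, though the uncertainty is wide.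

The expected result is a 1.3-fold higher number from compound 3 to compound 4 (0.12 log units; within the scatter). For compound 4 the estimated value is 2000 nM, with an expected range from 500 nM to 8000 nM.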

Compound 4, half-maximal inhibitory concentration: 2000 nM
Compound 4: the middle estimate sits on the measured number at the digits printed; the measured number falls inside the stated range.
By their numbers in this assay, from the lowest: compounds 3, 2 and 4 (each within the scatter of the next); then compound 1.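

In this assay, the place on the aromatic ring para to a large group accepts ethoxy as well as methyl, with a 1.3-fold higher number from compound 3 to compound 4 (0.12 log units; within the scatter), so a group with an added oxygen and a longer chain leaves the number within the scatter. Replacing fluoro there with ethoxy gives an 8.4-fold lower number from compound 1 to compound 4 (0.92 log units; beyond the scatter), so two different groups now stand apart from fluoro at this place, although compound 2, which keeps that fluoro and adds a second one, goes against any reading of fluoro alone as setting the high number. Nothing measured here explains these numbers.

The compounds shown leave open whether an amine, a carboxylic acid or a longer alkoxy chain at this place would stay with compound 3 and compound 4 or fall nearer compound 1. On these data alone, whether chloro or hydroxy would behave like fluoro also remains open.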